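The compounds below may be only part of what the source reports. "The series", "measured", "known", "first", "only" and "open" are said of these compounds alone.

Series notes. Compound 1 `CC1=C(C(=O)Nc2ccc(Br)cc2)C(c2ccc(Cl)cc2Cl)N=C(SCc2cccc(Cl)c2)N1` and compound 2 `CC1=C(C(=O)Nc2ccc(Br)cc2)C(c2ccc(Cl)cc2Cl)N=C(SCc2ccc(Cl)cc2)N1` share one core; compound 3 `CC1=C(C(=O)Nc2ccc([N+](=O)[O-])cc2)C(c2ccc(Br)cc2)N=C(SCc2cccc(Cl)c2)N1` and compound 4 `CC1=C(C(=O)Nc2ccc([N+](=O)[O-])cc2)C(c2ccc(Br)cc2)N=C(SCc2ccc(Cl)cc2)N1` share another, and the difference between the two cores is not broken down here. In a functional assay on the whole organism (artery, strain albino) with Rattus norvegicus as the target, with a stated time of 900 min, at a dose of 10 mg/kg by the oral route (on this read-out higher numbers stand for more inhibition at the one dose given (going by the name of the read-out) and lower numbers for less inhibition), compound 1 gives 7.2%. In this assay compound 2 gives 22.1%. The change 4-chlorophenyl in place of 3-chlorophenyl on a saturated chain carbon bound to a sulfur thus gives a number 14.9 percentage points higher from compound 1 to compound 2 (beyond the scatter). In this assay compound 3 gives 2.6%, the lowest of the three numbers, close to compound 1 and well apart from compound 2. Compound 4 carries the same change on the other core, (4-chlorophenyl in place of 3-chlorophenyl on a saturated chain carbon bound to a sulfur). For the measured compounds named here, the step from compound 3 to compound 4 in this assay is expected to be a number 13.4 percentage points higher from compound 3 to compound 4 (beyond the scatter), of the same order as the measured one, because the only difference between compound 1 and compound 2 is the same and gave a number 14.9 percentage points higher from compound 1 to compound 2 (beyond the scatter). Compound 4 is therefore estimated at 16% in this assay. Going by the values given here, the estimate for compound 4 is expected to lie between 4% and 30%; the core is different, and no measured step on that core is available, so the range is kept wide.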

Compound 4, a percentage reported as inhibition, in the whole organism at one dose (the size of the read-out at that dose, not a potency): 19%
Beside the measured number, compound 4's estimate is 3 percentage points below it; measured number inside the range.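

In this assay, 4-chlorophenyl in place of 3-chlorophenyl on a saturated chain carbon bound to a sulfur gives a number 16.4 percentage points higher from compound 3 to compound 4 (beyond the scatter). The change carries over between the two cores with a similar step: the same change on two cores in this assay, a number 14.9 percentage points higher (beyond the scatter) from compound 1 to compound 2 and a number 16.4 percentage points higher (beyond the scatter) from compound 3 to compound 4, 1.5 percentage points apart, within the scatter of two such steps. For the compounds shown here, this rests on only two pairs at one dose in one assay, so it shows neither a rule for other cores nor a potency difference, and it does not explain why the two chlorophenyl groups differ.

Still open, going by these compounds, is how an unsubstituted benzyl group or a longer alkyl chain would read in place of the chlorobenzyl group. On these data alone, the contribution of the differences between the two cores also remains open.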